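Removing the iodo group from compound 2

This account rests on a few compounds, and the source may have more. Where it says the series, first, only, none or still open, it means among the compounds named here.

Measured in a functional assay on HEL cells (Homo sapiens) for cytotoxicity, read by microscopy; on this read-out higher numbers stand for weaker inhibition and lower numbers for stronger inhibition:
- compound 1 `O=C1O/C(=C\Cn2cc(C(F)(F)F)c(=O)[nH]c2=O)C(OCc2ccccc2)=C1OCc1ccccc1` gives 2000 nM
- compound 2 `O=C1O/C(=C\Cn2cc(I)c(=O)[nH]c2=O)C(OCc2ccccc2)=C1OCc1ccccc1` gives 5000 nM

Compound 2 at 5000 nM holds the higher of the two numbers. Compound 3 `O=C1O/C(=C\Cn2ccc(=O)[nH]c2=O)C(OCc2ccccc2)=C1OCc1ccccc1` carries hydrogen in place of iodo on an aromatic carbon. Among the compounds with values here, only one measured step bears on this carbon: a 2.5-fold higher number from compound 1 to compound 2 (0.40 log units; beyond the scatter) is modest and swaps trifluoromethyl for iodo. Within the data shown here, no measured compound carries hydrogen there, so in this assay a step no larger than that one is expected, leaning to a higher number. The estimated change is a 1.6-fold higher number from compound 2 to compound 3 (0.20 log units; within the scatter) as expected from that single step. The estimate for compound 3 is 8000 nM (range 2500 nM to 25000 nM).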

Compound 3, half-maximal inhibitory concentration: 20000 nM
Compound 3: middle estimate off by 2.5-fold (0.40 log units), on the low side, within the range that was stated.
By their numbers in this assay, from the lowest: compound 1; then compound 2; then compound 3.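

In this assay hydrogen on this aromatic carbon gives the weakest inhibition of the three compounds, with a 4.0-fold higher number from compound 2 to compound 3 (0.60 log units; beyond the scatter) and a 10-fold higher number from compound 1 to compound 3 (1.00 log units; beyond the scatter) as the two steps. Both iodo and trifluoromethyl therefore go with stronger inhibition than hydrogen, which the comparison of those two groups alone could not show. No measurement here accounts for this order.

Going by these compounds, whether an amine, a carboxylic acid or a methyl group on this carbon would also give lower numbers than hydrogen stays open. Also open, on these data alone, is whether the order seen here holds on cells other than these.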